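This account rests on a few compounds, and the source may have more. Where it says the series, first, only, none or still open, it means among the compounds named here.

Measured so far:
- compound 1 `CCOc1ccc2nc(Nc3nc4ccc(F)cc4s3)sc2c1`, 39000 nM in a functional assay on THP-1 cells (Homo sapiens) for cytotoxicity, read by MTT assay, with a stated time of 48 h; on this read-out higher numbers stand for weaker inhibition and lower numbers for stronger inhibition
- compound 2 `CCOc1ccc2nc(Nc3nc4ccccc4s3)sc2c1`, 37100 nM in this assay
- compound 3 `Cc1ccc2nc(NC(=S)Nc3ccccc3)sc2c1`, only a limit in this assay: > 50000 nM

Compound 1 and compound 2 share one core and differ by a single change, (fluoro in place of hydrogen on an aromatic carbon). That step, a 1.1-fold higher number from compound 2 to compound 1 (0.02 log units; within the scatter), is within the scatter, so the two values show no order between them. Compound 3 carries another core; the difference between the cores of compound 3 and compound 2 is not broken down here. Compound 3 sits at the limit of this assay, (the limit of > 50000 nM in this assay, at which 1 of the 3 values shown sits).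

Compound 4 `Cc1ccc2nc(NC(=S)Nc3ccc(F)cc3)sc2c1` has not yet been measured in this assay. It differs from compound 3 by fluoro in place of hydrogen on an aromatic carbon. This is the same kind of change as that from compound 2 to compound 1, not the same one: there the fluorine entered a six-membered aromatic ring of carbon only that is part of a fused or bridged system of two rings, meta to a fused ring and para to a fused ring, whereas here it enters a six-membered aromatic ring of carbon only, para to a large group. The expectation for compound 4 rests on the step of a 1.1-fold higher number from compound 2 to compound 1 (0.02 log units; within the scatter) being within the scatter and on compound 3 standing at the limit (the limit of > 50000 nM in this assay, at which 1 of the 3 values shown sits). Compound 4 is therefore expected to move by about a step that the limit leaves unreadable from compound 3 to compound 4. Compound 4 is estimated at 55000 nM, between 30000 nM and 100000 nM, most likely reported only as a limit again.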

Compound 4, half-maximal inhibitory concentration: 36900 nM
Compound 4: the middle estimate sits 1.5-fold (0.17 log units) above what was measured, within the range that was stated.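

In this assay, the change from phenyl to 4-fluorophenyl gives an at least 1.3-fold lower number from compound 3 to compound 4 (0.13 log units; that floor lies within the scatter). Set beside the earlier step, the same change on the two cores reads: the same change on two cores in this assay, a 1.1-fold higher number (0.02 log units; within the scatter) from compound 2 to compound 1 and an at least 1.3-fold lower number (0.13 log units; that floor lies within the scatter) from compound 3 to compound 4; the limit leaves it open whether they differ. Going by these compounds, compound 3 has only a limit, > 50000 nM, so the size of the step on its core stays unknown, and the data show neither that the change carries over from one core to the other unaltered nor that it does not.

The compounds shown leave open how chloro or methoxy in place of the fluoro would read in this assay, since fluoro is the only group varied on these aromatic carbons. They also leave open whether a longer chain in place of the methyl group of compound 3 would give a measured number rather than a limit, which would allow this change to be read fully on that core.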